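Working notes: replacing the ring group on compound 2

A few compounds are considered here, and "the series" means these few. Any claim that something is new, unique, unknown or untested is made for them only; others in the source may bear on it.

Compound 1 `COC(=O)C1=C(C)N=C(C)/C(=C(/O)OC)C1c1cccc(OCc2nonc2C(N)=O)c1`: 3500 nM
Compound 2 `COC(=O)C1=C(C)N=C(C)/C(=C(/O)OC)C1c1ccccc1OCc1no[n+]([O-])c1C`: 43 nM

Both values come from a functional assay (aorta) with Rattus norvegicus as the target, in the presence of a further agent that is not named here; a lower number here means that less compound is needed, a higher number that more compound is needed for the effect. Of the two numbers, compound 2 has the lower at 43 nM, while compound 1 stands at 3500 nM, a gap beyond the usual scatter. Less of compound 2 is therefore needed for the effect. The two compounds differ in more than one place, so this gap does not measure the effect of any single change.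

The next compound to be measured is compound 3 `COC(=O)C1=C(C)N=C(C)/C(=C(/O)OC)C1c1ccccc1OCc1c(C#N)no[n+]1[O-]`. The change from compound 2 is a group of 8 heavy atoms (3 carbon, 3 nitrogen, 2 oxygen; one five-membered aromatic ring with 3 hetero atoms) in place of a group of 7 heavy atoms (3 carbon, 2 nitrogen, 2 oxygen; one five-membered aromatic ring with 3 hetero atoms), on a saturated chain carbon bound to an oxygen on an aromatic ring. Both groups contain one five-membered aromatic ring with 3 hetero atoms, and the entering group adds 1 triple bond outside aromatic rings. Within the data shown here, no measured step isolates this change, so the expectation is weakly founded. In this assay, no step beyond the scatter is expected, with a slight lean towards a lower number. The expected step is a 1.4-fold lower number from compound 2 to compound 3 (0.16 log units; within the scatter). For compound 3 the estimated value is 30 nM, with an expected range of 8 nM to 120 nM.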

Compound 3, half-maximal effective concentration: 9.4 nM
Compound 3: middle estimate off by 3.2-fold (0.50 log units), on the high side; low and high end bracket the measured number.
By their numbers in this assay, from the lowest: compound 3; then compound 2; then compound 1.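

In this assay, among these compounds, the exchange of ring groups on a saturated chain carbon bound to an oxygen on an aromatic ring gives a 4.6-fold lower number from compound 2 to compound 3 (0.66 log units; beyond the scatter) and is the first single-place step. This place therefore responds to a change in which the five-membered aromatic ring with 3 hetero atoms remains and 1 triple bond outside aromatic rings is added. Nothing available bears on why the number falls with this exchange.

Because the step replaces the whole ring group at once, it cannot show how much of the shift belongs to the nitrile and how much to other differences between the two groups. Going by these compounds, compound 1 differs from compound 2 and compound 3 in more than one place and does not settle this, and it remains open whether a different substituent on the ring at this place, such as a carboxylic acid, a trifluoromethyl group or a phenyl ring, would keep the number of compound 3 at 9.4 nM or move it in either direction.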